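Swapping thiophen-2-yl for phenyl: an estimate for compound 4

The source may hold more compounds than are shown below. What is called first, only, known or untested is meant among the compounds shown, and "the series" means these compounds.

Measured in a functional assay on HCT-116 cells (Homo sapiens) for cytotoxicity, read by MTT assay, with a stated time of 72 h; on this read-out lower numbers stand for stronger inhibition and higher numbers for weaker inhibition:
Compound 1 `COc1ccc(CNC(=O)c2nc(Br)c3cccnc3c2N[C@H]2CC[C@H](N)CC2)cc1`: 3000 nM
Compound 2 `N[C@H]1CC[C@H](Nc2c(C(=O)NCc3ccc(Cl)cc3Cl)nc(Br)c3cccnc23)CC1`: 6000 nM
Compound 3 `N[C@H]1CC[C@H](Nc2c(C(=O)NCc3cccs3)nc(Br)c3cccnc23)CC1`: "not determined" (no result reported)

Compound 3 has no number in this assay and so offers no starting point for a step. Compound 4 `N[C@H]1CC[C@H](Nc2c(C(=O)NCc3ccccc3)nc(Br)c3cccnc23)CC1` carries phenyl in place of thiophen-2-yl on a saturated chain carbon bound to an amide-type nitrogen and is otherwise the same. Among the compounds with values here, the only measured step bearing on this place is a 2.0-fold higher number from compound 1 to compound 2 (0.30 log units; within the scatter) and it stays within the scatter. No size or direction of step from compound 3 can therefore be expected, so the estimate rests on the values of compound 1 and compound 2 alone. Compound 4 is expected at about 4000 nM with an estimated range from 1500 nM to 10000 nM in this assay.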

Compound 4, half-maximal inhibitory concentration: 7000 nM
Compound 4: the middle estimate sits 1.8-fold (0.24 log units) below what was measured; the measured number falls inside the stated range.
By their numbers in this assay, from the lowest: compounds 1, 2 and 4 (each within the scatter of the next, the first and the last beyond it).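

In this assay the plain phenyl of compound 4 shows how this position reads with no substituent on the ring. Taking away both chlorines gives a 1.2-fold higher number from compound 2 to compound 4 (0.07 log units; within the scatter), whereas hydrogen in place of methoxy gives a 2.3-fold higher number from compound 1 to compound 4 (0.37 log units; beyond the scatter), the only step here that clears the scatter. Nothing measured here explains that modest step. Compound 3 has no number, so the change from thiophen-2-yl to phenyl cannot be read. From the compounds shown here alone, whether a pyridine ring in place of phenyl, or a carboxylic acid on it, would shift the value stays open.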